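Cytotoxicity Along a Small Series: From Compound 3 to Compound 4

The compounds below may be only part of what the source reports. "The series", "measured", "known", "first", "only" and "open" are said of these compounds alone.

Compound 1 `OB1OCc2ccc(-n3cccc3)cc21`: > 10 ug/mL
Compound 2 `NCc1ccc(C(=O)c2ccn(-c3ccc4c(c3)B(O)OC4)c2)cc1`: > 10 ug/mL
Compound 3 `Nc1ccc(C(=O)c2ccn(-c3ccc4c(c3)B(O)OC4)c2)cc1`: 3.9 ug/mL

All three were tested in an ADME assay on L929 cells (Mus musculus) for cytotoxicity, read by resazurin assay, with a stated time of 72 h; on this read-out lower numbers stand for stronger inhibition and higher numbers for weaker inhibition. For compound 1 the result is a limit of the assay, not a number. For compound 2 the result is likewise a limit. Among the compounds with values here, compound 3 is thus the only compound with a measured number; the other two sit at the limit (the limit of > 10 ug/mL in this assay, at which 2 of the 3 values shown sit). Within the data shown here, the one step between compounds differing in a single place, an at least 2.5-fold lower number from compound 2 to compound 3 (0.40 log units; beyond the scatter), is amino in place of aminomethyl on an aromatic carbon, and it moved the value from the limit to a number.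

Compound 4 `CCCCCC(=O)c1ccn(-c2ccc3c(c2)B(O)OC3)c1` differs from compound 3 by pentyl in place of 4-aminophenyl on a carbonyl carbon. Among the measured compounds shown here, no measured step covers this kind of change; the only step available touched the amine end of the same ring, whereas here the whole ring departs. With two of three results at the limit, compound 4 is expected to drift back toward it, an estimated step of a 2.1-fold higher number from compound 3 to compound 4 (0.31 log units; beyond the scatter). The estimate for compound 4 is 8 ug/mL, within 3 ug/mL to 20 ug/mL, and a limit alone may well be reported.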

Compound 4, half-maximal inhibitory concentration: > 10 ug/mL
Compound 4 gave a limit, no number; the forecaster's own chance of this, stated with the estimate: 50%; at least 1.2-fold (0.09 log units) between middle value and limit.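

In this assay, the change on the carbonyl carbon from 4-aminophenyl to pentyl gives an at least 2.5-fold higher number from compound 3 to compound 4 (0.40 log units; beyond the scatter), so the lower number of compound 3 does not survive the loss of the whole ring and its amine. Within the data shown here, the earlier step changed only the amine end of that ring, whereas this one shows that a chain with no ring and no nitrogen at this position also sits at the limit, leaving compound 3 as the only compound with a measured number: the limit of > 10 ug/mL in this assay, at which 3 of the 4 values shown sit. The steps from compound 1 and from compound 2 to compound 4 cannot be read, as both ends of each are limits.

Going by these compounds, whether a plain phenyl ring or a longer chain on this carbonyl carbon would give a number in this assay stays open. Also open, on these data alone, is whether an amine on the pentyl chain would do so.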